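Pyridinyl replaces hydroxycyclohexyl on the ethynyl arm

A few compounds are considered here, and "the series" means these few. Any claim that something is new, unique, unknown or untested is made for them only; others in the source may bear on it.

Two compounds share a common core and differ only at a triple-bonded carbon. Compound 1 `CONc1nc(C#CCCCC#N)nc2c1ncn2[C@@H]1O[C@H](CO)[C@@H](O)[C@H]1O` gives 282 nM in an assay on CHO cells for displacement of a labelled ligand from adenosine receptor A1 (Homo sapiens); on this read-out higher numbers stand for weaker inhibition and lower numbers for stronger inhibition. Compound 2 `CONc1nc(C#CC2CCCCC2O)nc2c1ncn2[C@@H]1O[C@H](CO)[C@@H](O)[C@H]1O` gives 34 nM in this assay. Among the measured compounds shown here, the single step between them, an 8.3-fold lower number from compound 1 to compound 2 (0.92 log units; beyond the scatter), is the only one measured, and it places compound 2 at the lower of the two numbers, with compound 1 the nearest neighbour at a higher number.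

Compound 3 `CONc1nc(C#Cc2ccccn2)nc2c1ncn2[C@@H]1O[C@H](CO)[C@@H](O)[C@H]1O` is not yet measured. It differs from compound 2 by pyridin-2-yl in place of 2-hydroxycyclohexyl on a triple-bonded carbon. The measured step from compound 1 to compound 2 bears on this only loosely, since it exchanged one non-aromatic substituent for another at the same place, and neither of those substituents resembles the aromatic group that enters here. For the measured compounds named here, no measured pair shows how this assay responds to such an exchange.

The expectation therefore rests on the measured step of an 8.3-fold lower number from compound 1 to compound 2 (0.92 log units; beyond the scatter), which shows that an exchange of substituents at this position moved the number only moderately. For compound 3 a step of a 2.1-fold higher number from compound 2 to compound 3 (0.31 log units; beyond the scatter) is expected, towards a somewhat higher number. Compound 3 is estimated at 70 nM, with a range from 15 nM to 300 nM.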

Compound 3, inhibition constant: 437 nM
For compound 3 the middle estimate is 6.2-fold (0.80 log units) below the measured one, outside the stated range (above it).
By their numbers in this assay, from the lowest: compound 2; then compounds 1 and 3 (each within the scatter of the next).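

In this assay, the step of a 13-fold higher number from compound 2 to compound 3 (1.11 log units; beyond the scatter) shows that a six-membered ring on the triple-bonded carbon does not by itself give the lower number, since 2-hydroxycyclohexyl and pyridin-2-yl both carry such a ring and still lie far apart. The step of a 1.5-fold higher number from compound 1 to compound 3 (0.19 log units; within the scatter) is within the scatter, so pyridin-2-yl and 3-cyanopropyl cannot be told apart here, even though one is an aromatic ring and the other an open chain, and among these three substituents the low number belongs to 2-hydroxycyclohexyl alone. The data shown offer no independent measurement that would explain this difference.

The exchange from compound 2 to compound 3 alters the ring from non-aromatic to aromatic and also removes the hydrogen-bond donor, and these compounds cannot separate the two changes; plain cyclohexyl, which lacks the hydroxyl, would bear on that question directly. Also open, on these data alone, is whether the ring nitrogen of pyridin-2-yl matters at all, a point on which phenyl or pyridin-3-yl at the same place would give a direct comparison.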